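The source may hold more compounds than are shown below. What is called first, only, known or untested is meant among the compounds shown, and "the series" means these compounds.

Compound 1 `O=C(/C=C/C(=O)N1C/C(=C\c2ccc([N+](=O)[O-])cc2)C(=O)/C(=C/c2ccc([N+](=O)[O-])cc2)C1)Nc1ccc(Cl)c(Cl)c1` gives 1700 nM in a functional assay on L1210 cells (Mus musculus) for cytotoxicity (a higher number here means a weaker inhibitor, a lower number a stronger inhibitor), the lowest of the two numbers recorded so far. Compound 2 `O=C(/C=C/C(=O)N1C/C(=C\c2ccccc2)C(=O)/C(=C/c2ccccc2)C1)Nc1ccc(Cl)cc1` gives 7800 nM in this assay, a higher number, and the gap between the two lies beyond the scatter. Compound 3 `O=C(/C=C/C(=O)N1C/C(=C\c2ccc([N+](=O)[O-])cc2)C(=O)/C(=C/c2ccc([N+](=O)[O-])cc2)C1)Nc1ccccc1` has not been measured; it differs from compound 1 in one place: phenyl in place of 3,4-dichlorophenyl on an amide-type nitrogen. For the measured compounds named here, with no measured pair isolating this change, the step is estimated to be a moderate loss, so the estimate for the step from compound 1 to compound 3 is a 2.1-fold higher number from compound 1 to compound 3 (0.31 log units; beyond the scatter). Compound 3 is expected to give 3500 nM, within 1500 nM to 8000 nM.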

Compound 3, half-maximal inhibitory concentration: 1800 nM
Estimate against measurement, compound 3: 1.9-fold (0.29 log units) above, and the stated range covers the measured number.
By their numbers in this assay, from the lowest: compounds 1 and 3 (each within the scatter of the next); then compound 2.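

In this assay, phenyl in place of 3,4-dichlorophenyl on the amide-type nitrogen gives a 1.1-fold higher number from compound 1 to compound 3 (0.02 log units; within the scatter). On the core of compound 1, then, the two chlorine atoms make no difference this read-out can resolve, and the position accepts the bare phenyl. Nothing available gives a reason for this result. Going by these compounds, it remains open whether this holds for groups of another kind at this place, such as a carboxylic acid or an amine on the phenyl, or a longer chain replacing it. On these data alone, whether the same change would be as silent on a core without the nitro groups also remains open.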